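A Branched Ester Swap Tested Against Cell Growth

The source may report more compounds than this note shows. Statements on the series, on what has been measured and on what is new or still open speak of the compounds shown alone.

Three compounds share one core. Compound 1 `Cc1ccc2c(=O)cc(/C=C/[S+](C)[O-])oc2c1` gives 2000 nM in a functional assay on A549 cells (Homo sapiens) for cytotoxicity, with a stated time of 48 h; a lower number here means a stronger inhibitor, a higher number a weaker inhibitor. Compound 2 `CC(C)CC(=O)Oc1ccc2oc(/C=C/[S+](C)[O-])cc(=O)c2c1` gives 2300 nM in this assay, and compound 3 `Cc1c(/C=C/[S+](C)[O-])oc2ccccc2c1=O` gives 1500 nM in this assay. Compound 2 has the highest of the three numbers, yet neither compound 1 nor compound 3 stands apart from it beyond the usual scatter, so the three sit together. Compound 4 `C[S+]([O-])/C=C/c1cc(=O)c2cc(OC(=O)C(C)(C)C)ccc2o1` is not yet measured. It differs from compound 2 in one place: tert-butyl in place of isobutyl on a carbonyl carbon. Among the measured compounds shown here, no measured pair shows this change, so its effect is unknown; the step expected for no change at the digits printed from compound 2 to compound 4 (within the scatter) is none beyond the scatter. Compound 4 is therefore estimated at 2300 nM in this assay, with a range from 1200 nM to 4500 nM.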

Compound 4, half-maximal inhibitory concentration: 1600 nM
Compound 4: the middle estimate sits 1.4-fold (0.16 log units) above what was measured; low and high end bracket the measured number.
By their numbers in this assay, from the lowest: compounds 3, 4, 1 and 2 (each within the scatter of the next).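

In this assay, tert-butyl in place of isobutyl on a carbonyl carbon gives a 1.4-fold lower number from compound 2 to compound 4 (0.16 log units; within the scatter), the first step read at this position. The same atoms joined differently in this group therefore do not separate the two esters in this read-out. No data at hand bear on the reason for this result.

The compounds shown leave open whether a longer chain, a phenyl ring or an amine on this carbonyl carbon would give a step beyond the scatter.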